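Swapping a Benzyl Ether for an Isobutyl Ether

This account rests on a few compounds, and the source may have more. Where it says the series, first, only, none or still open, it means among the compounds named here.

Compound 1, with the structure `O=C(/C=C/c1ccc(O)cc1)c1c(O)cccc1OCc1ccccc1`, has been tested in a functional assay on PC-3 cells (Homo sapiens) for antiproliferative activity, read by sulforhodamine B assay; on this read-out higher numbers stand for weaker inhibition of growth and lower numbers for stronger inhibition of growth. In this assay compound 1 gives > 30000 nM, which is a limit of the assay rather than a number, as the line the limit of > 30000 nM in this assay, at which 1 of the 2 values shown sits, records. For the measured compounds named here, compound 2, `CC(C)(C)CCOc1cccc(O)c1C(=O)/C=C/c1ccc(S(N)(=O)=O)cc1`, is the other compound measured so far, and in this assay compound 2 gives 3250 nM. Going by the values given here, compound 2 carries an alkyl ether and a sulfonamide instead of the benzyl ether and phenol of compound 1, so the two differ in more than one place and no single step between them can be read.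

Compound 3, `CC(C)COc1cccc(O)c1C(=O)/C=C/c1ccc(O)cc1`, has not yet been measured. It differs from compound 1 in one place: isopropyl in place of phenyl on a saturated chain carbon bound to an oxygen on an aromatic ring. Since compound 1 sits at a limit, the size of the step is uncertain, and a step toward stronger inhibition beyond the scatter is expected, as an at least 2.0-fold lower number from compound 1 to compound 3 (0.30 log units; that floor lies within the scatter). For compound 3 the estimated value is 15000 nM, with a range from 4000 nM to 60000 nM.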

Compound 3, concentration for 50% growth inhibition: 2970 nM
Compound 3: middle estimate off by 5.1-fold (0.70 log units), on the high side, outside the stated range (below it).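

For the compounds shown here, at the saturated chain carbon bound to an oxygen on an aromatic ring, replacing phenyl with isopropyl gives the first readable step in this assay, an at least 10-fold lower number from compound 1 to compound 3 (1.00 log units; beyond the scatter). This shows that, within this pair, a ring is not needed at this place for growth inhibition to reach a measurable level. Compound 1 gives > 30000 nM, which is a limit of the assay and not a number, so the step gives only a floor and not a full size: the limit of > 30000 nM in this assay, at which 1 of the 3 values shown sits.

As far as these compounds go, what remains open is whether the gain follows from losing the phenyl ring or from gaining the branched chain, a question that a cyclohexyl group at this place could help to settle. From the compounds shown here alone, how a plain methyl group or a chain ending in an amine would read at the same place is also open.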